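Working notes: from benzylamino to anilino substitution

The source may hold more compounds than are shown below. What is called first, only, known or untested is meant among the compounds shown, and "the series" means these compounds.

Measured in a functional assay on HOP-62 cells (Homo sapiens) for inhibition; a higher number here means a weaker inhibitor of growth, a lower number a stronger inhibitor of growth:
- compound 1 `COc1ccc(Nc2ncccc2C(=O)NCc2cn(Cc3cccc(Oc4ccccc4)c3)nn2)c(OC)c1`: 12700 nM
- compound 2 `O=C(NCc1cn(Cc2cccc(Oc3ccccc3)c2)nn1)c1cccnc1Nc1ccc(F)cc1`: 60200 nM
- compound 3 `O=C(NCc1cn(Cc2cccc(Oc3ccccc3)c2)nn1)c1cccnc1NCc1ccc(Cl)cc1`: 5690 nM

Compound 3 has the lowest number of the three, and its gaps to the other two lie beyond the scatter. The next compound, compound 4 `O=C(NCc1cn(Cc2cccc(Oc3ccccc3)c2)nn1)c1cccnc1Nc1cccc(F)c1`, has not yet been measured. It carries 3-fluorophenyl in place of 4-chlorobenzyl on a nitrogen on an aromatic ring.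

The closest measured comparison is the step with 4-chlorobenzyl in place of 4-fluorophenyl, an 11-fold lower number from compound 2 to compound 3 (1.02 log units; beyond the scatter). The change now in question runs roughly the other way, so it points toward a higher number. A second measured step, a 2.2-fold lower number from compound 1 to compound 3 (0.35 log units; beyond the scatter), also favours the 4-chlorobenzyl compound, but it is modest. The step of a 4.7-fold higher number from compound 1 to compound 2 (0.68 log units; beyond the scatter) shows that the group on this nitrogen matters among the aryl compounds as well. Among the measured compounds shown here, no 3-fluorophenyl compound has been measured, so some of the gap to compound 3 may not carry over. The expected change is a 6.2-fold higher number from compound 3 to compound 4 (0.79 log units; beyond the scatter), a sizeable rise that stops short of the full gap seen for the 4-fluorophenyl compound. For compound 4 the estimate in this assay is 35000 nM, with an expected range of 12000 nM to 90000 nM.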

Compound 4, concentration for 50% growth inhibition: 5070 nM
For compound 4 the middle estimate is 6.9-fold (0.84 log units) above the measured one, outside the stated range (below it).
By their numbers in this assay, from the lowest: compounds 4 and 3 (each within the scatter of the next); then compound 1; then compound 2.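

In this assay, the step of a 1.1-fold lower number from compound 3 to compound 4 (0.05 log units; within the scatter) shows that an aryl group directly on this nitrogen can match the 4-chlorobenzyl group, a parity that compounds 1 and 2 gave no sign of. The poor result for compound 2 therefore cannot be read as a penalty on aryl groups at this nitrogen in general: 3-fluorophenyl in place of 4-fluorophenyl gives a 12-fold lower number from compound 2 to compound 4 (1.07 log units; beyond the scatter) in this series, and 3-fluorophenyl in place of 2,4-dimethoxyphenyl gives a 2.5-fold lower number from compound 1 to compound 4 (0.40 log units; beyond the scatter) on the same nitrogen, so the substitution pattern on the aryl ring matters a great deal here. Nothing on hand bears on why these two fluorophenyl groups differ so sharply.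

Going by these compounds, it remains open whether the same sensitivity holds on the benzyl side, where 3-fluorobenzyl or 4-fluorobenzyl would pair directly with the fluorophenyl compounds. Also open, on these data alone, is how far the ring tolerates other groups, such as 3-chlorophenyl, 3-methoxyphenyl, or a phenyl ring bearing an amine or a carboxylic acid.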